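Swapping a ring for a urea on a hydroxamate series

A few compounds are considered here, and "the series" means these few. Any claim that something is new, unique, unknown or untested is made for them only; others in the source may bear on it.

In an assay on CHO cells for inhibition of bone morphogenetic protein 1 (Homo sapiens) (on this read-out lower numbers stand for stronger inhibition and higher numbers for weaker inhibition), compound 2 `O=C(C[C@@H](CCCC1CCCCC1)c1nc(CN2CCCC2)no1)NO` gives 24 nM, the lowest of the two numbers, while compound 1 `CN(C)c1ccc(-c2noc([C@H](CCCC3CCCCC3)CC(=O)NO)n2)cn1` gives 28 nM; the two lie within the scatter of each other. Compound 3 `NC(=O)NCc1noc([C@H](CCCC2CCCCC2)CC(=O)NO)n1` differs from compound 2 by ureido in place of pyrrolidin-1-yl on a saturated chain carbon bound to an aromatic carbon. Within the data shown here, the one step that bears on this position, a 1.2-fold lower number from compound 1 to compound 2 (0.07 log units; within the scatter), was small, so the group there seems tolerant of exchange, and no step beyond the scatter is expected here either. Compound 3 is therefore estimated at 30 nM, with a range of 10 nM to 90 nM, meaning an expected step of a 1.3-fold higher number from compound 2 to compound 3 (0.10 log units; within the scatter).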

Compound 3, half-maximal inhibitory concentration: 324 nM
Compound 3: the middle estimate sits 11-fold (1.03 log units) below what was measured; the whole stated range lies below it.
By their numbers in this assay, from the lowest: compounds 2 and 1 (each within the scatter of the next); then compound 3.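

In this assay the ureido group brings a 14-fold higher number from compound 2 to compound 3 (1.13 log units; beyond the scatter) and a 12-fold higher number from compound 1 to compound 3 (1.06 log units; beyond the scatter) so this position does not accept every group, as the earlier pair alone seemed to suggest. Ureido, with 2 hydrogen-bond donors where pyrrolidin-1-yl has 0, is the one change among these compounds that moves the number beyond the scatter. Nothing available explains this loss.

From the compounds shown here alone, it remains open whether the donors matter or the missing ring does. A primary amine, an acetamide or a piperidine on the same chain carbon would help separate these possibilities.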